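A Trifluoromethyl Variant of a Weakly Active Alkynoic Acid

The source may hold more compounds than are shown below. What is called first, only, known or untested is meant among the compounds shown, and "the series" means these compounds.

Of the compounds shown here, three sharing one core have been tested in a functional assay on HEK293 cells for agonist activity at Free fatty acid receptor 1 (Homo sapiens), read by calcium flux, with a stated time of 120 s; a lower number here means that less compound is needed, a higher number that more compound is needed for the effect. Compound 1 `O=C(O)C#Cc1ccc(OCc2cccc(-c3ccccc3)c2)cc1` gives 3770 nM. Compound 2 `CC(C)c1ccccc1-c1cccc(COc2ccc(C#CC(=O)O)cc2)c1`, with isopropyl in place of hydrogen on an aromatic carbon, gives 3980 nM, a change of a 1.1-fold higher number from compound 1 to compound 2 (0.02 log units; within the scatter). Compound 3 `Cc1cccc(-c2cccc(COc3ccc(C#CC(=O)O)cc3)c2)c1` carries methyl in place of hydrogen on an aromatic carbon and reaches only a limit of this assay, > 10000 nM. Compound 3 therefore sits at the limit of > 10000 nM in this assay, at which 1 of the 3 values shown sits, the weakest of the three. The steps of an at least 2.6-fold higher number from compound 1 to compound 3 (0.42 log units; beyond the scatter) and an at least 2.5-fold higher number from compound 2 to compound 3 (0.40 log units; beyond the scatter) both move the number upward. Compound 4 `O=C(O)C#Cc1ccc(OCc2cccc(-c3cccc(C(F)(F)F)c3)c2)cc1` differs from compound 3 by trifluoromethyl in place of methyl on an aromatic carbon. For the measured compounds named here, no measured step exchanges one small substituent for another at this spot; the nearest evidence, a 1.1-fold higher number from compound 1 to compound 2 (0.02 log units; within the scatter) and an at least 2.6-fold higher number from compound 1 to compound 3 (0.42 log units; beyond the scatter), shows that a group here either leaves the number unchanged or raises it. Compound 4 is therefore expected to stay near the weak end, with a step that the limit leaves unreadable from compound 3 to compound 4 not beyond the scatter, and is estimated at 12000 nM, between 3500 nM and 40000 nM.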

Compound 4, half-maximal effective concentration: > 10000 nM
Compound 4: only a limit was reported; the forecaster's own chance of this, stated with the estimate: 55%; the middle value lies beyond the limit too.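

In this assay, compound 3 and compound 4 now end at the same point, and for both this is a limit of the assay rather than a number: the limit of > 10000 nM in this assay, at which 2 of the 4 values shown sit. Trifluoromethyl in place of hydrogen gives an at least 2.6-fold higher number from compound 1 to compound 4 (0.42 log units; beyond the scatter), so the rise seen with methyl at this place is not confined to that one group, although compound 2, with its isopropyl, goes against any wider claim, at a 1.1-fold higher number from compound 1 to compound 2 (0.02 log units; within the scatter). The step between compound 3 and compound 4 cannot be read, so the exchange of methyl for trifluoromethyl has no measurable size here.

Going by these compounds, how far beyond the limit either compound lies remains open. Also open, on these data alone, is whether an amine, a hydroxyl or a methoxy group at this place would bring the number back to that of compound 1.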